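Loss of One Chloro Group Across Two Related Cores

The source may hold more compounds than are shown below. What is called first, only, known or untested is meant among the compounds shown, and "the series" means these compounds.

Compound 1 `ClCc1ccccc1Cn1cnc2c(Cl)nc(Cl)nc21` and compound 3 `ClCc1ccc(Cn2cnc3nc(Cl)nc(Cl)c32)cc1` are built from the same atoms joined differently; the difference between the two cores is not broken down here. In a functional assay on TK-10 cells (Homo sapiens) for cytotoxicity, read by sulforhodamine B assay, with a stated time of 48 h (a higher number here means a weaker inhibitor of growth, a lower number a stronger inhibitor of growth), compound 1 gives 2880 nM, while compound 3 gives 290 nM, the lowest number among the three measured compounds. Compound 2 `ClCc1ccccc1Cn1cnc2c(Cl)ncnc21` differs from compound 1 by hydrogen in place of chloro on an aromatic carbon, and in this assay compound 2 gives 46800 nM, so that a 16-fold higher number from compound 1 to compound 2 (1.21 log units; beyond the scatter). Compound 4 `ClCc1ccc(Cn2cnc3ncnc(Cl)c32)cc1` differs from compound 3 by hydrogen in place of chloro on an aromatic carbon, the same change at the same place in the ring. Resting on that single measured step, compound 4 is expected to shift by a comparable amount, a 16-fold higher number from compound 3 to compound 4 (1.20 log units; beyond the scatter), because a 16-fold higher number from compound 1 to compound 2 (1.21 log units; beyond the scatter) marks a large loss of growth inhibition for this change. Compound 4 is therefore estimated at 4600 nM, with a likely range from 1500 nM to 15000 nM.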

Compound 4, concentration for total growth inhibition: 2950 nM
Compound 4: middle estimate off by 1.6-fold (0.19 log units), on the high side, and the stated range covers the measured number.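

In this assay hydrogen in place of chloro on the carbon between two ring nitrogen atoms gives a 10-fold higher number from compound 3 to compound 4 (1.01 log units; beyond the scatter), and the change carries from one core to the other at much the same size: the same change on two cores in this assay, a 16-fold higher number (1.21 log units; beyond the scatter) from compound 1 to compound 2 and a 10-fold higher number (1.01 log units; beyond the scatter) from compound 3 to compound 4, 1.6-fold (0.20 log units) apart, within the scatter of two such steps. For the compounds shown here, this agreement rests on only two cores and a single assay. It does not show that the step would hold on any further core, nor why the chloro group matters.

The compounds shown leave open whether another group at that place, such as an amine or a methoxy group, would give a step of similar size. They also leave open what replacing the other ring chloro group, which stays in compound 2 and compound 4, would do.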